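This account rests on a few compounds, and the source may have more. Where it says the series, first, only, none or still open, it means among the compounds named here.

Two compounds share one core and differ only in the group on the outer phenyl of a urea. Compound 1 `COc1cc2ncnc(NCc3cccc(NC(=O)Nc4cccc(C)c4)c3)c2cc1OC` carries 3-methylphenyl there, and in a functional assay on HepG2 cells (Homo sapiens) for antiproliferative activity, read by MTT assay (a higher number here means a weaker inhibitor, a lower number a stronger inhibitor), compound 1 gives 21500 nM. Compound 2 `COc1cc2ncnc(NCc3cccc(NC(=O)Nc4ccc(C(C)(C)C)cc4)c3)c2cc1OC` carries 4-(tert-butyl)phenyl instead, and in this assay compound 2 gives 6850 nM. Across the pair, a 3.1-fold lower number from compound 1 to compound 2 (0.50 log units; beyond the scatter). Compound 2 thus stands with the lowest of the two numbers, and its nearest neighbour is compound 1, whose number is modestly higher.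

Compound 3 `COc1cc2ncnc(NCc3cccc(NC(=O)Nc4ccc(F)cc4)c3)c2cc1OC` changes the same position again: fluoro in place of tert-butyl on an aromatic carbon. Within the data shown here, only one measured step bears on this, a 3.1-fold lower number from compound 1 to compound 2 (0.50 log units; beyond the scatter), and it was modest in size; there a tert-butyl entered and the number went down, whereas here that tert-butyl leaves and a much smaller group takes its place. On that basis the expectation for compound 3 in this assay is a modest move back up, a 1.8-fold higher number from compound 2 to compound 3 (0.24 log units; within the scatter). The estimate for compound 3 is 12000 nM, expected to fall between 5000 nM and 30000 nM.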

Compound 3, half-maximal inhibitory concentration: 36600 nM
Compound 3: middle estimate off by 3.1-fold (0.48 log units), on the low side; the whole stated range lies below it.
By their numbers in this assay, from the lowest: compound 2; then compounds 1 and 3 (each within the scatter of the next).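

With the place on the outer ring held fixed, the change from 4-(tert-butyl)phenyl to 4-fluorophenyl isolates the group itself, and in this assay the tert-butyl compound keeps a clear edge (a 5.3-fold higher number from compound 2 to compound 3 (0.73 log units; beyond the scatter)). The first pair could not show this, since its two groups differed in both identity and ring position; the new pair also shows that a group at this position does not by itself give the lower number, as 4-fluorophenyl and 3-methylphenyl cannot be told apart (a 1.7-fold higher number from compound 1 to compound 3 (0.23 log units; within the scatter)), leaving compound 2 as the strongest inhibitor of the three. Nothing measured here gives a reason for the effect of this swap.

With only tert-butyl and fluoro at this position, the compounds shown cannot say whether the number falls steadily as the group gains heavy atoms or whether tert-butyl is a special case. A methyl, isopropyl or chloro group on that same carbon would help to separate these readings, and a tert-butyl on the carbon that holds the methyl in compound 1 would show how much the ring position matters.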